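The source may hold more compounds than are shown below. What is called first, only, known or untested is meant among the compounds shown, and "the series" means these compounds.

Compound 1 `COc1ccc2c(OCC[C@@H]3NC(=O)N(C)CCCC/C=C\[C@@H]4C[C@@]4(C(=O)NS(=O)(=O)C4(C)CC4)NC3=O)cc(-c3nc(C(C)C)cs3)nc2c1Cl` gives 37400 nM in an ADME assay on cells (Homo sapiens) for activation; a higher number here means that more compound is tolerated, a lower number that less compound is tolerated.
Compound 2 `COc1ccc2c(OCC[C@@H]3NC(=O)N(C)CCCC/C=C\[C@@H]4C[C@@]4(C(=O)NS(=O)(=O)C4CC4)NC3=O)cc(-c3nc(C(C)C)cs3)nc2c1Cl` gives 40400 nM in this assay.

Compound 2 and compound 1 sit within the scatter of each other, as the step of a 1.1-fold higher number from compound 1 to compound 2 (0.03 log units; within the scatter) shows. Compound 3 `C#CC1(S(=O)(=O)NC(=O)[C@@]23C[C@H]2/C=C\CCCCN(C)C(=O)N[C@@H](CCOc2cc(-c4nc(C(C)C)cs4)nc4c(Cl)c(OC)ccc24)C(=O)N3)CC1` differs from compound 2 by ethynyl in place of hydrogen on a saturated ring carbon. For the measured compounds named here, the one measured step, a 1.1-fold higher number from compound 1 to compound 2 (0.03 log units; within the scatter), exchanged a small group for hydrogen at the same saturated ring carbon and stayed within the scatter, so the same place appears tolerant of such a change. For compound 3 no step beyond the scatter is therefore expected, a 1.0-fold lower number from compound 2 to compound 3 (0.00 log units; within the scatter), and its value in this assay is estimated at 40000 nM (range 20000 nM to 80000 nM).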

Compound 3, half-maximal cytotoxic concentration: 26300 nM
Beside the measured number, compound 3's estimate is 1.5-fold (0.18 log units) above it, within the range that was stated.
By their numbers in this assay, from the lowest: compounds 3, 1 and 2 (each within the scatter of the next).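

On this saturated ring carbon of the three-membered ring, ethynyl now joins hydrogen and methyl, and in this assay both new steps stay within the scatter (a 1.5-fold lower number from compound 2 to compound 3 (0.19 log units; within the scatter); a 1.4-fold lower number from compound 1 to compound 3 (0.15 log units; within the scatter)). The place therefore accepts not only methyl but also a group of 2 heavy atoms containing a triple bond, with no readable shift in the amount of compound tolerated. Nothing measured here explains these small differences.

Going by these compounds, it remains open whether an amine, a carboxylic acid or a longer chain on this carbon would also stay within the scatter.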